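The source may report more compounds than this note shows. Statements on the series, on what has been measured and on what is new or still open speak of the compounds shown alone.

Series notes. Compound 1 `CN1C[C@H](C(=O)Nc2ccc(C#N)cc2)[C@@H](c2ccc(/C=C/C(=O)Nc3ccccc3N)cc2)C1` and compound 2 `CN1C[C@H](C(=O)Nc2ccc(F)c(Cl)c2)[C@@H](c2ccc(/C=C/C(=O)Nc3ccccc3N)cc2)C1` share the same core and differ only in the group on the amide-type nitrogen. Going by the values given here, in an in vitro ADME assay on microsomes from liver (Homo sapiens) for pharmacokinetics, read by LC-MS, with a stated time of 10 min, tested at 1 uM (a higher number here means faster removal of the compound, a lower number slower removal), compound 1 gives 1 mL/min/kg, the lowest of the two numbers so far; compound 2 gives 15 mL/min/kg. Among the compounds with values here, the single measured step, a 15-fold higher number from compound 1 to compound 2 (1.18 log units; beyond the scatter), shows that a change at this position can move the read-out a long way. Compound 3 `CN1C[C@H](C(=O)NC2CCCC2)[C@@H](c2ccc(/C=C/C(=O)Nc3ccccc3N)cc2)C1` alters the same position: cyclopentyl in place of 4-cyanophenyl on an amide-type nitrogen. Within the data shown here, no measured step covers an exchange of this kind, so the expectation leans on that one large step and on the scatter. Compound 3 is expected to run higher than compound 1, estimated at 8 mL/min/kg, within 2 mL/min/kg to 30 mL/min/kg, which means an expected step of an 8.0-fold higher number from compound 1 to compound 3 (0.90 log units; beyond the scatter).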

Compound 3, clearance: 9 mL/min/kg
Estimate against measurement, compound 3: 1.1-fold (0.05 log units) below, within the range that was stated.
By their numbers in this assay, from the lowest: compound 1; then compounds 3 and 2 (each within the scatter of the next).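

In this assay the large rise is no longer tied to a single replacement: a 9.0-fold higher number from compound 1 to compound 3 (0.95 log units; beyond the scatter) accompanies cyclopentyl, a non-aromatic ring of carbon only, while a 1.7-fold lower number from compound 2 to compound 3 (0.22 log units; within the scatter) leaves cyclopentyl and 3-chloro-4-fluorophenyl unseparated. An aromatic ring on the amide-type nitrogen therefore does not by itself give the low number, and compound 2 goes against any such pattern; among these three, only the 4-cyanophenyl of compound 1 stands apart. No supporting data bear on why this is so. As far as these compounds go, whether the nitrile carries the difference remains open. Unsubstituted phenyl, or a carboxylic acid or an amine in place of the nitrile, would test this.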